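The source may hold more compounds than are shown below. What is called first, only, known or untested is meant among the compounds shown, and "the series" means these compounds.

Compound 1 `O=[N+]([O-])c1ccc(-c2nnc(C3CCc4cc(F)ccc4O3)o2)cc1` and compound 2 `COc1cc(-c2nnc(C3CCc4cc(F)ccc4O3)o2)cc(OC)c1OC` share one core and differ in what sits on the six-membered aromatic ring of carbon only. In a functional assay (a lower number here means a stronger inhibitor, a higher number a weaker inhibitor), compound 1 gives 84800 nM, and compound 2 gives 87000 nM; compound 1 stands lowest of the two numbers, yet the gap to compound 2 lies within the scatter, so both read as weak inhibitors of about the same strength. Compound 3 `Fc1ccc2c(c1)CCC(c1nnc(-c3ccccc3)o1)O2` is compound 1 with hydrogen in place of nitro on an aromatic carbon. Among the compounds with values here, no measured pair shows this change, so the step of a 1.1-fold higher number from compound 1 to compound 3 (0.03 log units; within the scatter) is expected to stay small, in either direction or none beyond the scatter. Compound 3 is therefore estimated at 90000 nM, within 30000 nM to 270000 nM.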

Compound 3, half-maximal inhibitory concentration: 85900 nM
Estimate against measurement, compound 3: 1.0-fold (0.02 log units) above, within the range that was stated.
By their numbers in this assay, from the lowest: compounds 1, 3 and 2 (each within the scatter of the next).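

In this assay, within the data shown here, hydrogen in place of nitro on this aromatic carbon gives a 1.0-fold higher number from compound 1 to compound 3 (0.01 log units; within the scatter) and thus provides the first direct one-place comparison at this position. The weak inhibition seen with compound 1 therefore does not depend on the nitro group. Nothing measured here offers an explanation for this result. As far as these compounds go, whether another group at this position, such as an amine or a carboxylic acid, could move the number beyond the scatter remains open. So does whether changes elsewhere on the shared core would matter more.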